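This account rests on a few compounds, and the source may have more. Where it says the series, first, only, none or still open, it means among the compounds named here.

In an ADME assay on HEL cells (Homo sapiens) for cytotoxicity (on this read-out lower numbers stand for higher toxicity in this test and higher numbers for lower toxicity in this test), compound 2 `Cc1ccc(-[n+]2noc([O-])c2CN2CCN(c3cccc(Cl)c3)CC2)cc1` gives 38.2 ug/mL, the highest number among the three measured compounds. Compound 1 `[O-]c1on[n+](-c2ccc(Cc3ccc(-[n+]4noc([O-])c4CN4CCN(c5ccccc5)CC4)cc3)cc2)c1CN1CCN(c2ccccc2)CC1` gives 12 ug/mL and compound 3 `[O-]c1on[n+](-c2ccc(Cc3ccc(-[n+]4noc([O-])c4CN4CCCCC4)cc3)cc2)c1CN1CCCCC1` gives 12.6 ug/mL; both lie beyond the scatter below compound 2. Compound 4 `Cc1ccc(-[n+]2noc([O-])c2CN2CCN(c3ccccc3)CC2)cc1` differs from compound 2 in a single place: hydrogen in place of chloro on an aromatic carbon. Among the measured compounds shown here, no pair of measured compounds shows this change, so the expectation rests on compound 2 alone. The step of a 1.2-fold lower number from compound 2 to compound 4 (0.08 log units; within the scatter) in this assay is expected to stay within the usual scatter, or at most to move a little toward lower numbers. Compound 4 is therefore estimated at 32 ug/mL, with a range from 16 ug/mL to 65 ug/mL.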

Compound 4, half-maximal cytotoxic concentration: 20 ug/mL
For compound 4 the middle estimate is 1.6-fold (0.20 log units) above the measured one; the measured number falls inside the stated range.
By their numbers in this assay, from the lowest: compounds 1, 3, 4 and 2 (each within the scatter of the next, the first and the last beyond it).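

In this assay the change from 3-chlorophenyl to phenyl gives a 1.9-fold lower number from compound 2 to compound 4 (0.28 log units; within the scatter), the only direct reading of this position among the compounds shown. In this one pair, then, chloro on this aromatic carbon does not separate the two compounds beyond the scatter. Nothing measured here bears on the reason for this step. On these data alone, whether a methoxy group, a trifluoromethyl group or an amine on this carbon would move the number beyond the scatter remains open. So does whether the same change would read alike on another compound.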